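The source may hold more compounds than are shown below. What is called first, only, known or untested is meant among the compounds shown, and "the series" means these compounds.

Working notes on the amide series in an assay on HEK293 cells for inhibition of sodium channel protein type 10 subunit alpha (Homo sapiens), read by fluorescence; on this read-out lower numbers stand for stronger inhibition and higher numbers for weaker inhibition. Compound 1 `Cn1nccc1C(=O)Nc1ccc(-c2cc(Cl)cc(Cl)c2Cl)c(N)n1` gives 750 nM. Compound 2 `Cc1nocc1C(=O)Nc1ccc(-c2cc(Cl)cc(Cl)c2Cl)c(N)n1` shares its core and gives 670 nM. The two differ only by 1-methyl-1H-pyrazol-5-yl in place of 3-methyl-1,2-oxazol-4-yl on a carbonyl carbon, and the step of a 1.1-fold higher number from compound 2 to compound 1 (0.05 log units; within the scatter) shows that this swap barely moves the read-out. Compound 3 `COc1ccc(Cl)c(-c2ccc(NC(=O)c3conc3C)nc2N)c1` sits on a different core and gives 500 nM; the difference between its core and that of compound 2 is not broken down here, and the gap between the two values is within the scatter, so nothing can be said about one being stronger than the other.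

Compound 4 `COc1ccc(Cl)c(-c2ccc(NC(=O)c3ccnn3C)nc2N)c1` has not been measured. It relates to compound 3 exactly as compound 1 relates to compound 2: 1-methyl-1H-pyrazol-5-yl in place of 3-methyl-1,2-oxazol-4-yl on a carbonyl carbon. The place is the same in both pairs, so this is the same change, seen twice among the compounds here. Because a 1.1-fold higher number from compound 2 to compound 1 (0.05 log units; within the scatter) was flat, the step of a 1.1-fold higher number from compound 3 to compound 4 (0.05 log units; within the scatter) is expected to be small as well, with compound 4 estimated at 560 nM, likely between 280 nM and 1100 nM.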

Compound 4, half-maximal inhibitory concentration: 700 nM
Compound 4: the middle estimate sits 1.3-fold (0.10 log units) below what was measured, and the stated range covers the measured number.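

In this assay, 1-methyl-1H-pyrazol-5-yl in place of 3-methyl-1,2-oxazol-4-yl on a carbonyl carbon gives a 1.4-fold higher number from compound 3 to compound 4 (0.15 log units; within the scatter), so on this second core the change again stays within the scatter. Set beside the earlier step, the change carries over between the two cores with no difference that can be resolved: the same change on two cores in this assay, a 1.1-fold higher number (0.05 log units; within the scatter) from compound 2 to compound 1 and a 1.4-fold higher number (0.15 log units; within the scatter) from compound 3 to compound 4, 1.3-fold (0.10 log units) apart, within the scatter of two such steps. This shows that the two groups can stand in for each other on the core of compound 2 and the core of compound 3 within the resolution of the read-out; it does not show that the change would stay flat on any other core, and it cannot exclude a small dependence on the core hidden inside the scatter.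

As far as these compounds go, with only these two five-membered aromatic rings on the carbonyl carbon, it remains open whether an amine, a carboxylic acid or a longer alkyl chain in that place would move the number beyond the scatter. Going by these compounds alone, the difference between the two cores also remains open, as no single-place step separates them.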